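Branched alkyl ether replacing oxolanylmethyl ether on the aminoquinoline

The source may hold more compounds than are shown below. What is called first, only, known or untested is meant among the compounds shown, and "the series" means these compounds.

Compound 1 `CCOCC(C)Oc1cccc2ccc(N)nc12` gives 1070 nM in an assay on cells with melanin-concentrating hormone receptor 1 (Homo sapiens) as the target, read by radioligand binding; on this read-out higher numbers stand for weaker inhibition and lower numbers for stronger inhibition. Compound 2 `CCOCCOc1cccc2ccc(N)nc12` gives only the assay limit > 2000 nM in this assay. Compound 3 `Nc1ccc2cccc(OCC3CCCO3)c2n1` likewise gives only the limit > 2000 nM in this assay.

Compound 3 therefore stands at the limit of > 2000 nM in this assay, at which 2 of the 3 values shown sit, with no number of its own. Compound 4 `CC(C)C(C)Oc1cccc2ccc(N)nc12` differs from it by 1,2-dimethylpropyl in place of (oxolan-2-yl)methyl on an oxygen on an aromatic ring. For the measured compounds named here, two measured steps bear on this: an at least 1.8-fold higher number from compound 1 to compound 3 (0.27 log units; that floor lies within the scatter) and an at least 1.8-fold higher number from compound 1 to compound 2 (0.27 log units; that floor lies within the scatter), both floors that lie within the scatter. Compound 4 keeps a methyl on the chain carbon bound to the ring oxygen, as compound 1 does, but carries no second oxygen. Compound 4 is estimated at 1500 nM, between 500 nM and 5000 nM. The step this expectation means is an at least 1.3-fold lower number from compound 3 to compound 4 (0.12 log units; that floor lies within the scatter).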

Compound 4, half-maximal inhibitory concentration: 199 nM
Beside the measured number, compound 4's estimate is 7.5-fold (0.88 log units) above it; measured number below the stated range.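

In this assay, the group on the oxygen now makes a difference beyond the scatter: 1,2-dimethylpropyl gives an at least 10-fold lower number from compound 3 to compound 4 (1.00 log units; beyond the scatter) in place of (oxolan-2-yl)methyl, and an at least 10-fold lower number from compound 2 to compound 4 (1.00 log units; beyond the scatter) in place of 2-ethoxyethyl. With the methyl on the chain carbon kept, isopropyl in place of ethoxymethyl still gives a 5.4-fold lower number from compound 1 to compound 4 (0.73 log units; beyond the scatter). An oxygen in the chain is thus not needed for the lowest number of these four, which belongs to compound 4.

Going by these compounds, whether the branching or the loss of that oxygen carries the step stays open. On these data alone, what a straight pentyl chain, a longer chain or an amine on the chain would give also remains unknown.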